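This account rests on a few compounds, and the source may have more. Where it says the series, first, only, none or still open, it means among the compounds named here.

In a functional assay on CCRF-CEM cells (Homo sapiens) for inhibition, read by MTT assay, with a stated time of 72 h (on this read-out lower numbers stand for stronger inhibition and higher numbers for weaker inhibition), compound 2 (`COc1cc(NC(C)CCCNC(=O)NNC(=O)Nc2ccc(F)cc2)c2ncccc2c1`) gives 118000 nM and sits at the high end of the numbers shown. Compound 3 (`COc1cc(NC(C)CCCNC(=O)NNC(=O)Nc2ccc(Br)cc2)c2ncccc2c1`) is level with it at 110000 nM while compound 1 (`COc1cc(NC(C)CCCNC(=O)Nc2ccc(Br)cc2)c2ncccc2c1`) stands apart at 23000 nM on the low side. Compound 4 (`COc1cc(NC(C)CCCNC(=O)Nc2cccc(C(F)(F)F)c2)c2ncccc2c1`) is still unmeasured. It carries 3-(trifluoromethyl)phenyl in place of ((4-fluorophenyl)carbamoyl)amino on an amide-type nitrogen. Compound 1 likewise has a phenyl group directly on that nitrogen, so two modest steps bear most closely: a 5.1-fold higher number from compound 1 to compound 2 (0.71 log units; beyond the scatter) and a 4.8-fold higher number from compound 1 to compound 3 (0.68 log units; beyond the scatter) both lead away from that arrangement. Going by the values given here, the exchange of fluoro for bromo, a 1.1-fold lower number from compound 2 to compound 3 (0.03 log units; within the scatter) in size, stays within the scatter, although no measured compound carries 3-(trifluoromethyl)phenyl. A modest fall of similar size is therefore expected, and the estimated step in this assay is a 4.2-fold lower number from compound 2 to compound 4 (0.62 log units; beyond the scatter) in that direction. Compound 4 is expected at 28000 nM with an estimated range of 10000 nM to 75000 nM in this read-out.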

Compound 4, half-maximal inhibitory concentration: 19000 nM
Beside the measured number, compound 4's estimate is 1.5-fold (0.17 log units) above it; the range from low to high includes it.
By their numbers in this assay, from the lowest: compounds 4 and 1 (each within the scatter of the next); then compounds 3 and 2 (each within the scatter of the next).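

In this assay, 3-(trifluoromethyl)phenyl on the amide-type nitrogen gives a 6.2-fold lower number from compound 2 to compound 4 (0.79 log units; beyond the scatter) and a 5.8-fold lower number from compound 3 to compound 4 (0.76 log units; beyond the scatter) in place of the carbamoylamino groups, so a second phenyl group attached directly to that nitrogen also comes with numbers well apart from those of the longer carbamoylamino compounds. Between the two directly attached groups, 4-bromophenyl and 3-(trifluoromethyl)phenyl, the step is a 1.2-fold lower number from compound 1 to compound 4 (0.08 log units; within the scatter) and lies within the scatter, so these two different substituted phenyl groups cannot be told apart in this read-out. Nothing at hand accounts for these steps.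

The compounds shown leave open whether an aromatic ring is needed on that nitrogen at all, as a cyclohexyl ring or a plain methyl group there would show. They also leave open how a carboxylic acid or an amine on the phenyl ring would read, and what a longer chain to the shared core would do.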